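The source may hold more compounds than are shown below. What is called first, only, known or untested is meant among the compounds shown, and "the series" means these compounds.

Measured so far in a functional assay on A2780 cells (Homo sapiens) for inhibition, read by sulforhodamine B assay; a lower number here means a stronger inhibitor of growth, a higher number a weaker inhibitor of growth
- compound 1 `FC(F)(F)Oc1ccc(-c2ccc(-c3ccc(-c4nc5ccccc5[nH]4)cc3)cc2)cc1` gives 100000 nM
- compound 2 `Oc1cccc2[nH]c(-c3ccc(-c4ccc(-c5ccc(OC(F)(F)F)cc5)cc4)cc3)nc12` gives 2900 nM

Of these two, compound 2 has the lower number, at 2900 nM in this assay. Compound 3 `Oc1cccc2[nH]c(-c3ccc(-c4ccc(-c5cccc(Cl)c5)cc4)cc3)nc12` keeps the hydroxy of compound 2 and differs elsewhere: 3-chlorophenyl in place of 4-(trifluoromethoxy)phenyl on an aromatic carbon. Within the data shown here, the only measured step, a 34-fold lower number from compound 1 to compound 2 (1.54 log units; beyond the scatter), is large, but it belongs to the hydroxy in place of hydrogen, which compound 3 retains. Among the measured compounds shown here, no measured step covers the group that changes here, so the data give neither a size nor a direction for this change. The working expectation is therefore no step beyond the scatter, with a wide margin. The estimate amounts to a 1.2-fold lower number from compound 2 to compound 3 (0.06 log units; within the scatter). Compound 3 is expected at 2500 nM, with an estimated range of 600 nM to 10000 nM.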

Compound 3, concentration for 50% growth inhibition: 2800 nM
Compound 3: middle estimate off by 1.1-fold (0.05 log units), on the low side; the measured number falls inside the stated range.
By their numbers in this assay, from the lowest: compounds 3 and 2 (each within the scatter of the next); then compound 1.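

In this assay, among these compounds, 3-chlorophenyl in place of 4-(trifluoromethoxy)phenyl gives a 1.0-fold lower number from compound 2 to compound 3 (0.02 log units; within the scatter) with the hydroxy kept, the first reading of any change at this position on an aromatic carbon. The two groups read alike here, so the position accepts a smaller group holding chlorine and no oxygen or fluorine, at least in this one pair. Nothing available bears on why these two groups read alike.

Because both the substituent and its place on the ring change in this single step, the contribution of each stays unresolved. As far as these compounds go, whether this position would also hold a ring carrying an amine or a carboxylic acid, or a longer chain in place of the ring, remains open, as does how much of the value of compound 3 rests on the hydroxy.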